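Swapping the aromatic ring on the ring nitrogen

The compounds below may be only part of what the source reports. "The series", "measured", "known", "first", "only" and "open" are said of these compounds alone.

Measured compounds in an assay on HEK293 cells for inhibition of Voltage-dependent T-type calcium channel subunit alpha-1G (Homo sapiens), read by fluorescence, tested at 10 uM; on this read-out higher numbers stand for more inhibition at the one concentration tested (going by the name of the read-out) and lower numbers for less inhibition:
Compound 1, `CCCc1nc(-c2ccccc2)c(CNCCCN2CCN(c3cccc(OC)c3)CC2)o1`, gives 36.4%.
Compound 2, `CCCc1nc(-c2ccccc2)c(CNCCCN2CCN(c3ccc(C)cc3)CC2)o1`, gives 53.9%.
Compound 3, `CCCc1nc(-c2ccccc2)c(CNCCCN2CCN(c3ccccc3F)CC2)o1`, gives 54.4%.

Compound 3 has the highest of the three numbers, but the gap to compound 2 is small, a number 0.5 percentage points higher from compound 2 to compound 3 (within the scatter), so the two cannot be told apart; only compound 1 stands clearly lower, a number 18 percentage points higher from compound 1 to compound 3 (beyond the scatter).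

The next compound is compound 4, `CCCc1nc(-c2ccccc2)c(CNCCCN2CCN(c3ccc(Cl)cc3)CC2)o1`. Its change from compound 3 is 4-chlorophenyl in place of 2-fluorophenyl on an amine nitrogen in a ring. Within the data shown here, no measured step tests a chlorine on this ring. Among the measured compounds shown here, the step that comes closest is the one from compound 2 to compound 3, where another aromatic ring on the same ring nitrogen changed its substituent and the number barely moved, a number 0.5 percentage points higher from compound 2 to compound 3 (within the scatter); the step from compound 1 to compound 2, with a 4-methylphenyl entering, was a number 17.5 percentage points higher from compound 1 to compound 2 (beyond the scatter). Since compound 2 and compound 3 sit together, the expectation for compound 4 in this assay is a step of no real size, a number 0.6 percentage points higher from compound 3 to compound 4 (within the scatter). The estimate for compound 4 is 55%, within a range from 40% to 70%.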

Compound 4, a percentage reported as inhibition, at one concentration (the size of the read-out at that concentration, not a potency): 63.3%
Estimate against measurement, compound 4: 8.3 percentage points below; measured number inside the range.
By their numbers in this assay, from the lowest: compound 1; then compounds 2, 3 and 4 (each within the scatter of the next).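

Among these compounds, the new compound gives the first direct swap at a single spot on this aromatic ring, chloro in place of methyl, and in this assay that swap is a number 9.4 percentage points higher from compound 2 to compound 4 (within the scatter). The change of both substituent and its place on the ring from the 2-fluorophenyl is similarly small, a number 8.9 percentage points higher from compound 3 to compound 4 (within the scatter), so the 4-chlorophenyl, 4-methylphenyl and 2-fluorophenyl compounds form one group, while the 3-methoxyphenyl compound stays apart, a number 26.9 percentage points higher from compound 1 to compound 4 (beyond the scatter). Nothing available explains this separation.

A 4-methoxyphenyl or a 3-chlorophenyl group would help show whether the lower number of compound 1 goes with the methoxy group itself or with its place on the ring. On these data alone, what an unsubstituted phenyl or a pyridine ring on the same nitrogen would give also remains open.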